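From compound 2 to compound 4: carboxymethoxy to hydroxy

The source may report more compounds than this note shows. Statements on the series, on what has been measured and on what is new or still open speak of the compounds shown alone.

Of the compounds shown here, three have been read in an ADME assay on HEK293 cells (Homo sapiens) for cytotoxicity, with a stated time of 72 h (on this read-out higher numbers stand for an effect only at larger amounts of compound and lower numbers for an effect already at smaller amounts), and none of them gives a number. Compound 1 `O=C(Nc1ccc(F)c(-c2nc3ccccc3o2)c1)c1cc([N+](=O)[O-])ccc1Cl` gives > 25000 nM as a limit of the assay. Compound 2 `O=C(O)COc1cc(Cl)c(C(=O)Nc2cccc(-c3nc4ccccc4s3)c2)cc1[N+](=O)[O-]` gives > 25000 nM as a limit of the assay. Compound 3 `O=C(Nc1nc2ccc(Cl)cc2s1)c1cc([N+](=O)[O-])ccc1Cl` gives > 27000 nM as a limit of the assay. Compound 2 thus has no exact value and sits at the limit of > 25000 nM in this assay, at which 2 of the 3 values shown sit, in the series.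

Compound 4 `O=C(Nc1cccc(-c2nc3ccccc3s2)c1)c1cc([N+](=O)[O-])c(O)cc1Cl` is related to compound 2 by hydrogen in place of carboxymethyl on an oxygen on an aromatic ring with hydrogen in place of carboxymethyl on an oxygen on an aromatic ring. Going by the values given here, no measured step gives a size for this change. The expectation therefore rests on compound 2 with > 25000 nM as its limit. The expected a number no higher from compound 2 to compound 4 (the limit leaves the size open) stays within the usual scatter, with no direction favoured. Compound 4 is estimated at 25000 nM (expected range 10000 nM to 50000 nM) in this assay and a report of only a limit is the likeliest outcome.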

Compound 4, half-maximal effective concentration: > 25000 nM
Compound 4 was reported as a limit; the forecaster's own chance of this, stated with the estimate: 75%; the middle value sits exactly at the limit.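

Going by these compounds alone, compound 2 and compound 4 are both reported only as limits, and no step between them can be read. The compounds shown leave open where any of them would give an exact value, and whether hydrogen in place of carboxymethyl changes the read-out at all.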